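Compound 3 to compound 4: a larger ring group

A few compounds are considered here, and "the series" means these few. Any claim that something is new, unique, unknown or untested is made for them only; others in the source may bear on it.

In a functional assay on HGC-27 cells (Homo sapiens) for antiproliferative activity, read by MTT assay, with stated times of 72 h and 4 h (a lower number here means a stronger inhibitor, a higher number a weaker inhibitor), compound 3 `COc1ncc(-c2cc3c(N4CC(OC)C4)ncnc3s2)cc1NS(=O)(=O)c1ccc(F)cc1F` gives 830 nM and compound 1 `COc1ncc(-c2cc3c(N4CCCCC4)ncnc3s2)cc1NS(=O)(=O)c1ccc(F)cc1F` gives 1200 nM, two numbers within the scatter of each other (a 1.4-fold lower number from compound 1 to compound 3 (0.16 log units; within the scatter)). Compound 2 `COc1ncc(-c2cc3c(N4CCCC4)ncnc3s2)cc1NS(=O)(=O)c1ccc(F)cc1F` gives 2300 nM, which places compound 3 clear of it only: a 2.8-fold lower number from compound 2 to compound 3 (0.44 log units; beyond the scatter), while a 1.9-fold higher number from compound 1 to compound 2 (0.28 log units; within the scatter).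

Compound 4 `COc1ncc(-c2cc3c(N4CC5COCC5C4)ncnc3s2)cc1NS(=O)(=O)c1ccc(F)cc1F` differs from compound 3 by a group of 8 heavy atoms (6 carbon, 1 nitrogen, 1 oxygen; 2 five-membered non-aromatic rings with 1 hetero atom each) in place of a group of 6 heavy atoms (4 carbon, 1 nitrogen, 1 oxygen; one four-membered non-aromatic ring with 1 hetero atom), on an aromatic carbon. Among the measured compounds shown here, the three measured swaps at this place are the only guide, and the largest of them, the modest step from compound 2, sets the scale. For the measured compounds named here, no measured compound carries the entering group, so the direction stays open, and no step beyond the scatter is expected in this assay. The expected step is a 1.3-fold higher number from compound 3 to compound 4 (0.12 log units; within the scatter). For compound 4 the estimated value is 1100 nM, with an expected range of 450 nM to 2600 nM.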

Compound 4, half-maximal inhibitory concentration: 300 nM
Estimate against measurement, compound 4: 3.7-fold (0.56 log units) above; measured number below the stated range.
By their numbers in this assay, from the lowest: compound 4; then compounds 3, 1 and 2 (each within the scatter of the next, the first and the last beyond it).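

At this place on the core, the group with 2 five-membered non-aromatic rings takes the number in this assay beyond the scatter against all three single-ring groups (a 2.8-fold lower number from compound 3 to compound 4 (0.44 log units; beyond the scatter); a 4.0-fold lower number from compound 1 to compound 4 (0.60 log units; beyond the scatter); a 7.7-fold lower number from compound 2 to compound 4 (0.88 log units; beyond the scatter)). Among the compounds shown here, compound 4 is thus the only compound of the four clear of every other, whereas among the earlier three, compound 3 stood clear of compound 2 alone. No supporting data bear on what lies behind this step.

Open, as far as these compounds go, is whether the second ring or its oxygen accounts for the step. A morpholin-4-yl group, or the same two rings with carbon in place of that oxygen, would bear on this.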